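The source may report more compounds than this note shows. Statements on the series, on what has been measured and on what is new or still open speak of the compounds shown alone.

Working notes on the series. Compound 1 `CNC(=O)[C@H]1O[C@@H](n2cnc3c(NCc4cc(OC)ccc4OC)ncnc32)[C@H](O)[C@@H]1O` and compound 2 `CNC(=O)[C@H]1O[C@@H](n2cnc3c(NCc4cc(Cl)ccc4OCc4ccccc4)ncnc32)[C@H](O)[C@@H]1N` share the same core and are measured in an assay on isolated protein for binding affinity to adenosine receptor A3 (Homo sapiens) (on this read-out higher numbers stand for weaker inhibition and lower numbers for stronger inhibition), where compound 1 gives 3.9 nM and compound 2 gives 16 nM. Compound 2 thus stands at the higher of the two numbers; the two values show a gap that is beyond the usual scatter. Compound 3 `CNC(=O)[C@H]1O[C@@H](n2cnc3c(NCc4cc(Cl)ccc4OCC(=O)N4CCCCC4)ncnc32)[C@H](O)[C@@H]1N` is not yet measured. It differs from compound 2 in one place: (piperidin-1-yl)carbonyl in place of phenyl on a saturated chain carbon bound to an oxygen on an aromatic ring. Within the data shown here, no measured pair shows this change, so the step is expected to be small in either direction or none beyond the scatter, with compound 3 estimated at 25 nM (range 8 nM to 80 nM) in this assay. The step from compound 2 to compound 3 is thus expected as a 1.6-fold higher number from compound 2 to compound 3 (0.19 log units; within the scatter).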

Compound 3, inhibition constant: 18 nM
The estimate for compound 3 lay 1.4-fold (0.14 log units) above the measured number; the measured number falls inside the stated range.
By their numbers in this assay, from the lowest: compound 1; then compounds 2 and 3 (each within the scatter of the next).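

In this assay, (piperidin-1-yl)carbonyl in place of phenyl on a saturated chain carbon bound to an oxygen on an aromatic ring gives a 1.1-fold higher number from compound 2 to compound 3 (0.05 log units; within the scatter), so the aromatic ring of carbon only is not required at this position for binding in this range. The added hydrogen-bond acceptor and the non-aromatic ring together leave the number within the scatter. Nothing on hand bears on why this step is so small. Open, on these data alone, is how an amine, a carboxylic acid or a longer chain at this place would read, and whether the same change holds on the core of compound 1.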